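This account rests on a few compounds, and the source may have more. Where it says the series, first, only, none or still open, it means among the compounds named here.

Working notes on the series. In a functional assay on NCI-H460 cells (Homo sapiens) for cytotoxicity, read by sulforhodamine B assay, with a stated time of 48 h (a higher number here means a weaker inhibitor of growth, a lower number a stronger inhibitor of growth), compound 1 `ClCc1ccccc1Cn1cnc2c(Cl)nc(Cl)nc21` gives 8710 nM. Compound 2 `ClCc1cccc(Cn2cnc3ncnc(Cl)c32)c1` gives 4460 nM in this assay, and compound 3 `ClCc1ccc(Cn2cnc3c(Cl)nc(Cl)nc32)cc1` gives 4900 nM in this assay. Within the data shown here, compound 1 has the highest of the three numbers, but its gap to compound 3 and its gap to compound 2 both lie within the usual scatter, so no order among the three compounds can be read from these values, and no single-point step between measured compounds is available for comparison.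

Compound 4 `Nc1nc(Cl)c2ncn(Cc3ccccc3CCl)c2n1` differs from compound 1 by amino in place of chloro on an aromatic carbon, on the six-membered aromatic ring of the shared core, between two ring nitrogen atoms. Nothing measured in this set shows what such an exchange does in this assay. The expected step from compound 1 to compound 4 in this assay, a 1.0-fold higher number from compound 1 to compound 4 (0.01 log units; within the scatter), is small and of no firm direction, not beyond the scatter. Compound 4 is estimated at 9000 nM in this assay, with a range from 3000 nM to 30000 nM.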

Compound 4, concentration for total growth inhibition: 37200 nM
Estimate against measurement, compound 4: 4.1-fold (0.62 log units) below; measured number above the stated range.
By their numbers in this assay, from the lowest: compounds 2, 3 and 1 (each within the scatter of the next); then compound 4.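

In this assay, amino in place of chloro on an aromatic carbon, between two ring nitrogen atoms, gives a 4.3-fold higher number from compound 1 to compound 4 (0.63 log units; beyond the scatter). Among these compounds, this is the first single-place step, and it shows that this position of the shared core is not indifferent to substitution: of this pair, compound 1, with the chloro group, is the stronger inhibitor of growth. Nothing at hand accounts for the direction or size of this step.

A single exchange at one position gives no trend, so the compounds shown leave open whether a methoxy or a methylamino group there would track with amino or with chloro. Also open, as far as these compounds go, is whether amino in place of chloro at this position would give a similar step on compound 3.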